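Fluoro for Triazole: Clearance Outlook for Compound 4

The compounds below may be only part of what the source reports. "The series", "measured", "known", "first", "only" and "open" are said of these compounds alone.

Measured so far, in an ADME assay on microsomes from liver (Canis lupus familiaris) for metabolic stability, read by LC-MS, using NADPH, with a stated time of 10 min, tested at 0.1 uM; a higher number here means faster removal of the compound, a lower number slower removal:
compound 1 `O=C(NCCCCc1ccccc1)c1cccc(C2SCC(=O)N2c2cccc(-c3c[nH]nn3)c2)c1`, 226 mL.min-1.g-1
compound 2 `COc1ccccc1N1C(=O)C(C)SC1c1cccc(C(=O)NCCCCc2ccccc2)c1`, 1170 mL.min-1.g-1
compound 3 `O=C(NCCCCn1cccn1)c1cccc(C2SCC(=O)N2c2ccccn2)c1`, 88.9 mL.min-1.g-1

Compound 1 sits second highest of the three numbers in this assay. Its nearest neighbour is compound 3, whose value of 88.9 mL.min-1.g-1 lies beyond the scatter below it, and its furthest is compound 2, whose value of 1170 mL.min-1.g-1 lies beyond the scatter above it. Among the measured compounds shown here, none of the three pairs differs in only one place, so no single step between measured compounds can be drawn on.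

The step under consideration leads from compound 1 to compound 4 `O=C(NCCCCc1ccccc1)c1cccc(C2SCC(=O)N2c2cccc(F)c2)c1`, the change being (fluoro in place of 1H-1,2,3-triazol-4-yl on an aromatic carbon). For the measured compounds named here, no directly comparable step has been measured. Compound 1 carries the ring with three hetero atoms and one hydrogen-bond donor; compound 4 carries a single fluorine atom there. Because compound 2, which carries no such ring, gives 1170 mL.min-1.g-1, the expectation for this assay is a step upward from compound 1 to compound 4, of moderate size and beyond the scatter, a 2.7-fold higher number from compound 1 to compound 4 (0.42 log units; beyond the scatter). Compound 4 is therefore estimated at 600 mL.min-1.g-1, with a range from 250 mL.min-1.g-1 to 1400 mL.min-1.g-1.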

Compound 4, intrinsic clearance in microsomes: 837 mL.min-1.g-1
For compound 4 the middle estimate is 1.4-fold (0.14 log units) below the measured one; measured number inside the range.
By their numbers in this assay, from the lowest: compound 3; then compound 1; then compounds 4 and 2 (each within the scatter of the next).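

In this assay, fluoro in place of 1H-1,2,3-triazol-4-yl gives a 3.7-fold higher number from compound 1 to compound 4 (0.57 log units; beyond the scatter). This is the first step among these compounds in which only one place changes, and it shows that this aromatic carbon, meta to a large group, is not a silent position: with the rest of compound 1 held the same, exchanging a five-membered aromatic ring with 3 hetero atoms for a single fluorine atom moves intrinsic clearance in microsomes upward, beyond the usual scatter. No evidence on the properties of either group bears on this result, so the reason for the rise remains unknown.

Still open, as far as these compounds go, is whether the rise belongs to the departure of 1H-1,2,3-triazol-4-yl or to the arrival of fluoro, a question that a plain hydrogen, a nitrile or a tetrazole on that same carbon could help to separate. Also open, from the compounds shown here alone, is whether the step keeps its direction and size when the amide chain is changed, for instance to one ending in an amine or a carboxylic acid.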